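A few compounds are considered here, and "the series" means these few. Any claim that something is new, unique, unknown or untested is made for them only; others in the source may bear on it.

Working notes on the series. Compound 1 `C(=C/CN(C[C@H]1Cc2ccccc2CN1)[C@H]1CCCc2cccnc21)\CNCC1CCOCC1` is the reference structure, carrying the (oxan-4-yl)methyl amine. In a functional assay on cells for agonist activity at C-X-C chemokine receptor type 4 (Homo sapiens), read by fluorescence and calcium flux, with a stated time of 90 s (on this read-out lower numbers stand for an effect already at smaller amounts and higher numbers for an effect only at larger amounts of compound), compound 1 gives > 30000 nM, which is a limit of the assay and not a number. Compound 2 `FC1(F)CCC(NC/C=C/CN(C[C@H]2Cc3ccccc3CN2)[C@H]2CCCc3cccnc32)CC1` differs from compound 1 by 4,4-difluorocyclohexyl in place of (oxan-4-yl)methyl on an amine nitrogen. The corresponding step, a step that the two limits leave unreadable from compound 1 to compound 2, cannot be sized from the two values. Compound 2 gives > 30000 nM in this assay, again a limit. Compound 3 `CC(C)(CCN(C[C@H]1Cc2ccccc2CN1)[C@H]1CCCc2cccnc21)CNCC1CCOCC1` carries a different core; how it differs from the core of compound 1 is not broken down here. Compound 3 gives > 30000 nM in this assay, also a limit. Going by the values given here, compound 4 `CC(C)(CCN(C[C@H]1Cc2ccccc2CN1)[C@H]1CCCc2cccnc21)CNC1CCC(F)(F)CC1` is not yet measured and differs from compound 3 by 4,4-difluorocyclohexyl in place of (oxan-4-yl)methyl on an amine nitrogen, the same change as the one made from compound 1 to compound 2. For compound 4 the expected step is a step that the limit leaves unreadable from compound 3 to compound 4, which rests on the limit of > 30000 nM in this assay, at which 3 of the 3 values shown sit, together with the unreadable a step that the two limits leave unreadable from compound 1 to compound 2. Compound 4 is therefore estimated at 40000 nM in this assay, with a range from 10000 nM to 150000 nM, most probably reported as a limit.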

Compound 4, half-maximal effective concentration: > 30000 nM
Compound 4: a limit, no number; the forecaster's own chance of this, stated with the estimate: 80%; the middle value is on the limit's open side.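

In this assay compound 4 gives > 30000 nM, a limit of the assay and not a number. Compound 3 also stands at a limit, so no step can be read from compound 3 to compound 4. The compounds shown leave open whether 4,4-difluorocyclohexyl in place of (oxan-4-yl)methyl on an amine nitrogen changes the half-maximal effective concentration at all, because every value sits at one limit: the limit of > 30000 nM in this assay, at which 4 of the 4 values shown sit.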